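This account rests on a few compounds, and the source may have more. Where it says the series, first, only, none or still open, it means among the compounds named here.

Measured compounds:
compound 1 `COc1cc(N)c(Cl)cc1NC(=O)C1CCN(CC2CCCCCC2)CC1` — > 10 mg/kg
compound 2 `CCC(CC)CN1CCC(C(=O)Nc2cc(Cl)c(N)cc2OC)CC1` — > 10 mg/kg
compound 3 `COc1cccc(CN2CCC(C(=O)Nc3cc(Cl)c(N)cc3OC)CC2)c1` — > 4 mg/kg

In a functional assay on the whole organism for antagonist activity, with Mus musculus as the target (a higher number here means that more compound is needed for the effect, a lower number that less compound is needed), compound 1 gives > 10 mg/kg, which is a limit of the assay. Compound 2 gives > 10 mg/kg, also a limit. Compound 3 gives > 4 mg/kg, again a limit, so compound 3 stands at no number, and the two other values shown are limits as well (the limit of > 10 mg/kg in this assay, at which 2 of the 3 values shown sit, (the limit of > 4 mg/kg in this assay, at which 1 of the 3 values shown sits)). The steps a step that the two limits leave unreadable from compound 1 to compound 2, a step that the two limits leave unreadable from compound 1 to compound 3 and a step that the two limits leave unreadable from compound 2 to compound 3 are therefore unreadable in size. Compound 4 `COc1cc(N)c(Cl)cc1NC(=O)C1CCN(Cc2ccsc2)CC1` differs from compound 3 by thiophen-3-yl in place of 3-methoxyphenyl on a saturated chain carbon bound to an amine nitrogen in a ring. Among the compounds with values here, no measured step bears on this change, and the three unreadable steps give no direction. In this assay the expected step is a step that the limit leaves unreadable from compound 3 to compound 4, none beyond the scatter. Compound 4 is estimated at 8 mg/kg, within 2 mg/kg to 30 mg/kg, and most likely reported again only as a limit.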

Compound 4, dose for half-maximal effect: 3.4 mg/kg
The estimate for compound 4 lay 2.4-fold (0.37 log units) above the measured number; the measured number falls inside the stated range.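

In this assay compound 4 is the only compound shown with a number rather than a limit, which gives the place on a saturated chain carbon bound to an amine nitrogen in a ring its first readable value. Thiophen-3-yl in that place gives an at least 2.9-fold lower number from compound 1 to compound 4 (0.46 log units; beyond the scatter) and an at least 2.9-fold lower number from compound 2 to compound 4 (0.46 log units; beyond the scatter). Against 3-methoxyphenyl the result is only an at least 1.1-fold lower number from compound 3 to compound 4 (0.07 log units; that floor lies within the scatter), so no gain over compound 3 can be claimed.

The steps among compound 1, compound 2 and compound 3 still cannot be read. On these data alone, whether furan-3-yl or unsubstituted phenyl in this place would hold the number of compound 4 remains open.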